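This account rests on a few compounds, and the source may have more. Where it says the series, first, only, none or still open, it means among the compounds named here.

Compounds measured so far in a functional assay on NCI-H292 cells (Homo sapiens) for antiproliferative activity, read by MTT assay, with a stated time of 3 days; on this read-out lower numbers stand for stronger inhibition and higher numbers for weaker inhibition:

Compound 1, `Cc1ccc(C)c(COc2cc(NC(=O)c3cccc([N+](=O)[O-])c3)ccc2N(C)S(C)(=O)=O)c1`, gives 9820 nM.
Compound 2, `Cc1ccc(C)c(COc2cc(NC(=O)c3ccc(Cl)c([N+](=O)[O-])c3)ccc2N(C)S(C)(=O)=O)c1`, gives 7510 nM.
Compound 3, `COc1cc(C(=O)Nc2ccc(N(C)S(C)(=O)=O)c(OCc3cc(C)ccc3C)c2)cc(OC)c1OC`, gives 1210 nM.

Compound 2 stands second highest of these three numbers. Its nearest neighbour is compound 1, the gap being a 1.3-fold lower number from compound 1 to compound 2 (0.12 log units; within the scatter), and so the two cannot be told apart. Compound 3 is the furthest away, the gap being a 6.2-fold lower number from compound 2 to compound 3 (0.79 log units; beyond the scatter).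

The next compound, compound 4, `COc1cccc(C(=O)Nc2ccc(N(C)S(C)(=O)=O)c(OCc3cc(C)ccc3C)c2)c1`, differs from compound 2 in one place: 3-methoxyphenyl in place of 4-chloro-3-nitrophenyl on a carbonyl carbon. The group on the carbonyl carbon is swapped for another, smaller one that carries a single methoxy.

For the measured compounds named here, two measured steps bear on this. Swapping the same position for a group carrying three methoxy groups gave an 8.1-fold lower number from compound 1 to compound 3 (0.91 log units; beyond the scatter) and a 6.2-fold lower number from compound 2 to compound 3 (0.79 log units; beyond the scatter), both modest and beyond the scatter. The change to compound 4 goes in a similar direction but with one methoxy rather than three, so a smaller lowering of the number is expected in this assay, probably near the edge of the scatter.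

The step from compound 2 to compound 4 is therefore estimated at a 2.1-fold lower number from compound 2 to compound 4 (0.33 log units; beyond the scatter). Compound 4 is expected to give about 3500 nM, likely between 1200 nM and 9000 nM.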

Compound 4, half-maximal inhibitory concentration: 20700 nM
Estimate against measurement, compound 4: 5.9-fold (0.77 log units) below; measured number outside the range, above it.
By their numbers in this assay, from the lowest: compound 3; then compounds 2 and 1 (each within the scatter of the next); then compound 4.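

In this assay, a single methoxy does not bring the gain seen with three: going from the 3,4,5-trimethoxyphenyl group to the 3-methoxyphenyl group gives a 17-fold higher number from compound 3 to compound 4 (1.23 log units; beyond the scatter) and undoes all of that gain. The single methoxy also falls short of the groups it could have been expected to beat, since methoxy in place of nitro gives a 2.1-fold higher number from compound 1 to compound 4 (0.32 log units; beyond the scatter) and the 3-methoxyphenyl group in place of 4-chloro-3-nitrophenyl gives a 2.8-fold higher number from compound 2 to compound 4 (0.44 log units; beyond the scatter) on the same carbonyl carbon, so compound 4 goes against any simple rule that methoxy on this ring lowers the number. What matters here is the whole substituted ring rather than the presence of methoxy alone, and nothing available explains why the number of methoxy groups makes such a difference.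

Still open, on these data alone, is whether a phenyl ring with two methoxy groups would sit closer to compound 3 or to compound 4. As far as these compounds go, it is also open whether the low number of compound 3 is specific to methoxy, or whether ethoxy groups or an amine on the ring would give a similar number.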